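The compounds below may be only part of what the source reports. "The series", "measured", "known", "first", "only" and "open" are said of these compounds alone.

Of the compounds shown here, three sharing one core have been measured. Compound 1 `CCCc1cc(N)c2cc(NC(=O)/C=C/c3ccccc3)ccc2n1` gives 1000 nM in an assay on isolated protein for displacement of a labelled ligand from melanin-concentrating hormone receptor 1 (Homo sapiens); on this read-out higher numbers stand for weaker inhibition and lower numbers for stronger inhibition. Compound 2 `CCCc1cc(N)c2cc(NC(=O)/C=C/c3ccc(CC)cc3)ccc2n1` gives 1.4 nM in this assay. Compound 3 `CCCc1cc(N)c2cc(NC(=O)/C=C/c3ccc(Cl)c(Cl)c3)ccc2n1` gives 60 nM in this assay, which is the second highest of the three numbers: the nearest neighbour is reached by the step of a 17-fold lower number from compound 1 to compound 3 (1.22 log units; beyond the scatter), and the furthest by the step of a 43-fold higher number from compound 2 to compound 3 (1.63 log units; beyond the scatter).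

Compound 4 `CCCc1cc(N)c2cc(NC(=O)/C=C/c3ccccc3Cl)ccc2n1` differs from compound 3 in one place: 2-chlorophenyl in place of 3,4-dichlorophenyl on a double-bonded chain carbon bound to a double-bonded chain carbon. The change keeps a chlorine-bearing phenyl but drops one chlorine and moves the remaining one.

Going by the values given here, two measured steps bear on this. The step of a 17-fold lower number from compound 1 to compound 3 (1.22 log units; beyond the scatter) shows that placing two chlorines on the phenyl lowered the number, and the step of a 710-fold lower number from compound 1 to compound 2 (2.85 log units; beyond the scatter) shows that an ethyl on the same ring lowered it far more. Among the compounds with values here, no measured compound carries a 2-chlorophenyl, so the effect of a single chlorine in that position is unknown. A single chlorine is expected to recover only part of the gain seen with two, so the step of a 4.2-fold higher number from compound 3 to compound 4 (0.62 log units; beyond the scatter) is expected to go upward beyond the scatter. Compound 4 is therefore estimated at 250 nM, within a range of 60 nM to 1500 nM.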

Compound 4, half-maximal inhibitory concentration: 120 nM
Compound 4: middle estimate off by 2.1-fold (0.32 log units), on the high side; the measured number falls inside the stated range.
By their numbers in this assay, from the lowest: compound 2; then compounds 3 and 4 (each within the scatter of the next); then compound 1.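

In this assay, a single chlorine on the phenyl ring is enough for a clear gain: chloro in place of hydrogen gives an 8.3-fold lower number from compound 1 to compound 4 (0.92 log units; beyond the scatter). Replacing 3,4-dichlorophenyl with 2-chlorophenyl gives a 2.0-fold higher number from compound 3 to compound 4 (0.30 log units; within the scatter), so losing one chlorine and having the other sit elsewhere on the ring, taken together, produce no difference that can be told from the scatter. The 4-ethylphenyl group remains far better than 2-chlorophenyl, with an 86-fold higher number from compound 2 to compound 4 (1.93 log units; beyond the scatter), so neither chlorinated ring shown comes close to it.

No available evidence explains any of these differences. Still open, going by these compounds, is whether the count or the place of the chlorines matters more, since the two change together here, and whether a methoxy group or a chain longer than ethyl on the phenyl ring would match the ethyl.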